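Series notes: aryl group on the ring nitrogen

The source may hold more compounds than are shown below. What is called first, only, known or untested is meant among the compounds shown, and "the series" means these compounds.

Of the compounds shown here, three of the shared core have been measured so far. Compound 1 `CCc1ccc(-n2cc(C(=O)N3CCCCCC3)c3cc(OC)c(OC)cc3c2=O)cc1` gives 570 nM in an assay on CHO cells for antagonist activity at lysophosphatidic acid receptor 5 (Rattus norvegicus), read by cAMP accumulation, with a stated time of 30 min; on this read-out higher numbers stand for weaker inhibition and lower numbers for stronger inhibition. Compound 2 `COc1cc2c(C(=O)N3CCCCCC3)cn(-c3ccc(C)c(C)c3)c(=O)c2cc1OC` gives 720 nM in this assay, and the step of a 1.3-fold higher number from compound 1 to compound 2 (0.10 log units; within the scatter) is within the scatter. Compound 3 `CCN1CCc2ccc(-n3cc(C(=O)N4CCCCCC4)c4cc(OC)c(OC)cc4c3=O)cc21` gives 110 nM, the lowest of the three numbers; its nearest neighbour is compound 1, its furthest compound 2, and both steps to it, a 5.2-fold lower number from compound 1 to compound 3 (0.71 log units; beyond the scatter) and a 6.5-fold lower number from compound 2 to compound 3 (0.82 log units; beyond the scatter), lie beyond the scatter.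

Compound 4 `COc1cc2c(C(=O)N3CCCCCC3)cn(-c3ccc(F)cc3)c(=O)c2cc1OC` has not yet been measured. Its change from compound 3 is 4-fluorophenyl in place of 1-ethyl-2,3-dihydro-1H-indol-6-yl on an aromatic nitrogen. The two steps that bear on it run the other way: the 1-ethyl-2,3-dihydro-1H-indol-6-yl group entering in place of a plain phenyl carrying small alkyl groups gave lower numbers both times, so its departure in favour of a phenyl carrying a single fluorine is expected to raise the number again, by a step of about the same size as those, or somewhat larger given that 4-fluorophenyl is smaller still than the groups of compound 1 and compound 2. The expected step is an 8.2-fold higher number from compound 3 to compound 4 (0.91 log units; beyond the scatter). For compound 4 the estimate in this assay is 900 nM, with a range from 300 nM to 2700 nM.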

Compound 4, half-maximal inhibitory concentration: > 3000 nM
Compound 4 was reported as a limit (the forecaster's own chance of this, stated with the estimate: 5%); middle value at least 3.3-fold (0.52 log units) away from the limit.
By their numbers in this assay, from the lowest: compound 3; then compounds 1 and 2 (each within the scatter of the next). At a limit, above all of these: compound 4.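

In this assay compound 4 stands only as a limit: the limit of > 3000 nM in this assay, at which 1 of the 4 values shown sits. Among these compounds, at this position the aryl group on the aromatic nitrogen can therefore move the read-out further than the earlier compounds showed, with an at least 27-fold higher number from compound 3 to compound 4 (1.43 log units; beyond the scatter) now the widest step, and its true size is open at the upper end. Among the compounds shown here, the phenyl groups also separate for the first time: 4-ethylphenyl and 3,4-dimethylphenyl stood within the scatter of each other, whereas 4-fluorophenyl parts from both, with an at least 4.1-fold higher number from compound 2 to compound 4 (0.61 log units; beyond the scatter) and an at least 5.2-fold higher number from compound 1 to compound 4 (0.72 log units; beyond the scatter), so fluoro in place of ethyl on an aromatic carbon is a change this assay registers.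

Going by these compounds, how far compound 4 lies past its limit remains unknown, so these steps give only minimum sizes and cannot rank 4-fluorophenyl any more finely against the other groups. Also open, on these data alone, is whether the low number of compound 3 depends on the ethyl on the ring nitrogen of its 1-ethyl-2,3-dihydro-1H-indol-6-yl group, which a methyl or a longer chain there would test, and whether a chloro or a methoxy at the place of the fluoro would follow the ethyl or the fluoro.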